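A few compounds are considered here, and "the series" means these few. Any claim that something is new, unique, unknown or untested is made for them only; others in the source may bear on it.

Values in a functional assay with Oryctolagus cuniculus as the target; a higher number here means a weaker inhibitor, a lower number a stronger inhibitor:
- Compound 1 `CNC(=N)Nc1nc(-c2ccc(OC)cc2)c(-c2ccc(OC)cc2)s1` gives 62 nM
- Compound 2 `CC/N=C(/N)Nc1nc(-c2ccc(OC)cc2)c(-c2ccc(OC)cc2)s1` gives > 100 nM (a limit of the assay, not a number)
- Compound 3 `COc1ccc(-c2nc(/N=C(\N)N(C)C)sc2-c2ccc(OC)cc2)cc1` gives 37 nM

Compound 3 holds one of the two exact numbers, and the gap to the other is small: a 1.7-fold lower number from compound 1 to compound 3 (0.22 log units; within the scatter). Against the limit, the difference is clearer: an at least 2.7-fold lower number from compound 2 to compound 3 (0.43 log units; beyond the scatter).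

Compound 4 `COc1ccc(-c2nc(/N=C(\N)NC3CCCCC3)sc2-c2ccc(OC)cc2)cc1` carries cyclohexylamino in place of dimethylamino on a carbon with a double bond to nitrogen.

Two other measured steps bear on this change, since both alter the same side group. The first is an at least 1.6-fold higher number from compound 1 to compound 2 (0.20 log units; that floor lies within the scatter), and the second is the step to compound 3 already given. Together they hint that compound 2 lost some inhibition, but compound 3 goes against any simple rule that a larger group inhibits less. A moderate rise in the number is therefore expected, with weaker inhibition. The estimated change is a 3.2-fold higher number from compound 3 to compound 4 (0.51 log units; beyond the scatter). Compound 4 is expected at about 120 nM, within an estimated range of 30 nM to 500 nM.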

Compound 4, half-maximal inhibitory concentration: > 1000 nM
Compound 4 ended at the assay's limit; the forecaster's own chance of this, stated with the estimate: 45%; at least 8.3-fold (0.92 log units) between middle value and limit.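

For the compounds shown here, changing the group on a carbon with a double bond to nitrogen can cost far more inhibition in this assay than the earlier compounds revealed, as cyclohexylamino in place of dimethylamino gives an at least 27-fold higher number from compound 3 to compound 4 (1.43 log units; beyond the scatter). Compound 4 stands at a limit of the assay, not at a number: the limit of > 1000 nM in this assay, at which 1 of the 4 values shown sits. The comparison with the smaller group of compound 1 points the same way, with an at least 16-fold higher number from compound 1 to compound 4 (1.20 log units; beyond the scatter), so this position does not accept every group in this assay.

Compound 2 and compound 4 both stand at limits, so the step between them cannot be read. A single cyclohexylamino compound cannot separate the effect of the ring from that of its size, and cyclopropylamino or an open hexylamino chain at this position would bear on that question.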